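The source may report more compounds than this note shows. Statements on the series, on what has been measured and on what is new or still open speak of the compounds shown alone.

Measured compounds:
- compound 1, `O=S(=O)(c1cccc(F)c1)c1cn(C2CCNC2)c2ccc(Cl)cc12`, gives 15 nM in an assay on HeLa cells for displacement of a labelled ligand from 5-hydroxytryptamine receptor 6 (Homo sapiens), with a stated time of 2 h; on this read-out lower numbers stand for stronger inhibition and higher numbers for weaker inhibition
- compound 2, `O=S(=O)(c1ccccc1)c1cn(C2CCN(Cc3ccccc3)CC2)c2ccccc12`, gives 49 nM in this assay
- compound 3, `COc1ccc2c(S(=O)(=O)c3cccc(Cl)c3)cn(C3CCNC3)c2c1`, gives 4.6 nM in this assay

Of the three numbers, compound 1 stands second highest. Compound 3 sits nearest to it with a lower number, and compound 2 furthest with a higher number; both gaps lie beyond the usual scatter, so compound 1 is separated from each. For the measured compounds named here, three compounds with different cores and different amine rings give no single-point comparison, so no step between measured compounds is available.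

Compound 4, `O=S(=O)(c1cccc(F)c1)c1cn(C2CCNC2)c2ccccc12`, differs from compound 1 in one place: hydrogen in place of chloro on an aromatic carbon. The chloro sits on the six-membered carbon-only ring of the fused system, meta and para to the fused ring, and nothing else in the structure moves. Going by the values given here, with no measured pair showing what this chloro contributes, the expectation rests on compound 1 alone, and a modest weakening is expected, with a 2.3-fold higher number from compound 1 to compound 4 (0.37 log units; beyond the scatter) lying near the edge of the scatter. Compound 4 is estimated at 35 nM, within 12 nM to 100 nM.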

Compound 4, inhibition constant: 4.7 nM
Beside the measured number, compound 4's estimate is 7.4-fold (0.87 log units) above it; the measured number lies below the stated range.
By their numbers in this assay, from the lowest: compounds 3 and 4 (each within the scatter of the next); then compound 1; then compound 2.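

Hydrogen in place of chloro gives the series its first single-place comparison: in this assay, the step is a 3.2-fold lower number from compound 1 to compound 4 (0.50 log units; beyond the scatter). On this position, meta to a fused ring and para to a fused ring, the chloro is therefore not needed for a low number, and with the rest of compound 1 unchanged, its presence goes with weaker inhibition. Nothing shown accounts for the size of this step.

On these data alone, whether the weakening is particular to chloro or would also appear with another group here, such as bromo, methyl or nitrile, remains open. This single pair also cannot show whether the same change would hold with the amine ring of compound 2 or with the other substituents of compound 3.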